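The source may hold more compounds than are shown below. What is called first, only, known or untested is meant among the compounds shown, and "the series" means these compounds.

Measured compounds in an assay on CHO cells for antagonist activity at transient receptor potential cation channel subfamily V member 1 (Homo sapiens), read by FLIPR; on this read-out lower numbers stand for stronger inhibition and higher numbers for weaker inhibition:

compound 1, `CCCCN(C)c1cc(C(F)(F)F)ccc1CNC(=O)C(C)c1ccc(NS(C)(=O)=O)c(F)c1`, 1.2 nM
compound 2, `CC(C(=O)NCc1ccc(C(F)(F)F)cc1N1CCCC1)c1ccc(NS(C)(=O)=O)c(F)c1`, 2.3 nM
compound 3, `CC(C)COc1cc(C(F)(F)F)ccc1CNC(=O)C(C)c1ccc(NS(C)(=O)=O)c(F)c1`, 0.8 nM

Compound 3 has the lowest of the three numbers in this assay. Its gap to compound 1 is small: the step of a 1.5-fold lower number from compound 1 to compound 3 (0.18 log units; within the scatter) is within the scatter, so the two cannot be ranked against each other. Its gap to compound 2 is larger, the step of a 2.9-fold lower number from compound 2 to compound 3 (0.46 log units; beyond the scatter), which is beyond the scatter though modest. The step of a 1.9-fold higher number from compound 1 to compound 2 (0.28 log units; within the scatter) is again within the scatter.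

Compound 4, `CC(C(=O)NCc1ccc(C(F)(F)F)cc1OCc1ccccc1)c1ccc(NS(C)(=O)=O)c(F)c1`, differs from compound 3 in one place: phenyl in place of isopropyl on a saturated chain carbon bound to an oxygen on an aromatic ring. Among the measured compounds shown here, none of the measured steps touches this position. All three exchange the whole substituent on the aromatic carbon, and the two that involve compound 3 only show that an isobutoxy there gives a number as low as, or lower than, the two amines. For the measured compounds named here, no measured compound varies the chain beyond the oxygen, so there is nothing that shows how a larger group there would read.

With that, the change from compound 3 to compound 4 is estimated to move the number by no more than the scatter, a 1.9-fold higher number from compound 3 to compound 4 (0.27 log units; within the scatter). Compound 4 is therefore expected to give about 1.5 nM in this assay, with a range from 0.4 nM to 6 nM.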

Compound 4, inhibition constant: 0.9 nM
Estimate against measurement, compound 4: 1.7-fold (0.22 log units) above, and the stated range covers the measured number.
By their numbers in this assay, from the lowest: compounds 3, 4, 1 and 2 (each within the scatter of the next, the first and the last beyond it).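

In this assay, among the compounds shown here, the chain beyond the oxygen can be read for the first time, and the exchange of isopropyl for phenyl at this place gives a 1.1-fold higher number from compound 3 to compound 4 (0.05 log units; within the scatter), so a larger group with an aromatic ring of carbon only, 6 heavy atoms where there were 3, leaves the number indistinguishable from that of the isobutoxy compound. Set against the amines, benzyloxy reads as isobutoxy did: the exchange for pyrrolidin-1-yl gives a 2.6-fold lower number from compound 2 to compound 4 (0.41 log units; beyond the scatter), a modest step beyond the scatter, while the exchange for butyl(methyl)amino gives a 1.3-fold lower number from compound 1 to compound 4 (0.12 log units; within the scatter), which does not separate the two. Nothing given here explains why the number stays put at this position.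

The compounds shown leave open how the chain would read with a further carbon between the oxygen and the phenyl, as in a 2-phenylethoxy group, or with a phenyl carrying a nitrile or a carboxylic acid. From the compounds shown here alone, all four also keep the trifluoromethyl group on the ring, so whether isobutoxy and benzyloxy would still match with a chlorine in its place remains unknown.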